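Thioester tail variation on a piperidine-linked pyrimidine ether series

The compounds below may be only part of what the source reports. "The series", "measured", "known", "first", "only" and "open" are said of these compounds alone.

Measured compounds:
- compound 1, `Cc1nc(S(C)(=O)=O)ccc1Oc1ncnc(OC2CCN(C(=O)OC3CCC3)CC2)c1F`: 167 nM
- compound 2, `Cc1nc(S(C)(=O)=O)ccc1Oc1ncnc(OC2CCN(C(=O)SC(C)(C)C)CC2)c1F`: 30.7 nM

Both compounds share one core and differ only in the group attached to the carbonyl carbon of the carbamate-like tail. In a functional assay on isolated protein for inhibition of Glucose-dependent insulinotropic receptor (Rattus norvegicus), read by HTRF and cAMP accumulation (a lower number here means that less compound is needed, a higher number that more compound is needed for the effect), compound 1 gives 167 nM, and compound 2 gives 30.7 nM. Among the measured compounds shown here, the single measured step, a 5.4-fold lower number from compound 1 to compound 2 (0.74 log units; beyond the scatter), comes from putting (tert-butyl)sulfanyl in place of cyclobutyloxy on that carbonyl carbon. For the measured compounds named here, compound 2 therefore stands with the lowest number of the two measured, its only neighbour being compound 1 with the higher number.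

Compound 3, `Cc1nc(S(C)(=O)=O)ccc1Oc1ncnc(OC2CCN(C(=O)SC3(C)CC3)CC2)c1F`, keeps the thioester tail of compound 2 and changes only the group on the sulfur: 1-methylcyclopropyl in place of tert-butyl on a sulfur. Going by the values given here, no measured step speaks to this particular change; the step from compound 1 to compound 2 altered the atom joined to the carbonyl and the whole group beyond it, whereas here the sulfur stays and only the carbon group swaps for another of the same size. With nothing measured pointing one way or the other, the expected step of a 1.1-fold higher number from compound 2 to compound 3 (0.06 log units; within the scatter) is none beyond the scatter. Compound 3 is accordingly estimated at 35 nM, within a range of 12 nM to 100 nM.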

Compound 3, half-maximal effective concentration: 166 nM
Beside the measured number, compound 3's estimate is 4.7-fold (0.68 log units) below it, and the stated range ends below it.
By their numbers in this assay, from the lowest: compound 2; then compounds 3 and 1 (each within the scatter of the next).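

In this assay, the carbon group on the sulfur turns out to matter in its own right: 1-methylcyclopropyl in place of tert-butyl, with the same count of 4 heavy atoms, gives a 5.4-fold higher number from compound 2 to compound 3 (0.73 log units; beyond the scatter), so matching that count does not keep the number of compound 2. The lower number of compound 2 therefore cannot be credited to the sulfur alone, since the comparison with the oxygen-linked tail shows a 1.0-fold lower number from compound 1 to compound 3 (0.00 log units; within the scatter), which lies within the scatter even though compound 3 carries the sulfur and compound 1 does not. Nothing measured here explains why tert-butyl and 1-methylcyclopropyl part ways on this sulfur.

The compounds shown leave open whether tert-butyloxy on the same carbonyl carbon would stay close to tert-butylsulfanyl, a pairing that would separate the effect of the linking atom from that of the carbon group. Also open, from the compounds shown here alone, is how a cyclobutyl group or a longer chain such as n-butyl on the sulfur, or an amine on the carbonyl carbon, would compare with compound 2 and compound 3.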